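Removing one methoxy from compound 2

The source may report more compounds than this note shows. Statements on the series, on what has been measured and on what is new or still open speak of the compounds shown alone.

In a functional assay on PC-3 cells (Homo sapiens) for cytotoxicity, read by MTT assay, with a stated time of 72 h (on this read-out lower numbers stand for stronger inhibition and higher numbers for weaker inhibition), compound 2 (`COc1cc(/C=C/C(=O)Nc2cc3c(Nc4ccc(F)c(Cl)c4)ncnc3cc2O[C@H]2CCOC2)cc(OC)c1OC`) gives 20500 nM, within the scatter of compound 1 (`COc1ccc(OC)c(/C=C/C(=O)Nc2cc3c(Nc4ccc(F)c(Cl)c4)ncnc3cc2OC)c1`) at 28600 nM and of compound 3 (`COc1cc2ncnc(Nc3ccc(F)c(Cl)c3)c2cc1NC(=O)/C=C/c1cc(OC)c(OC)c(OC)c1`) at 38200 nM. Compound 4 (`COc1cc(/C=C/C(=O)Nc2cc3c(Nc4ccc(F)c(Cl)c4)ncnc3cc2O[C@H]2CCOC2)cc(OC)c1`) differs from compound 2 in one place: hydrogen in place of methoxy on an aromatic carbon. This is hydrogen in place of methoxy on an aromatic carbon, so 3,4,5-trimethoxyphenyl becomes 3,5-dimethoxyphenyl. Among the compounds with values here, no measured step makes this exact change. The closest one swaps 2,5-dimethoxyphenyl for 3,4,5-trimethoxyphenyl and gives a 1.3-fold higher number from compound 1 to compound 3 (0.13 log units; within the scatter). Methyl in place of oxolan-3-yl, at another place, gives a 1.9-fold higher number from compound 2 to compound 3 (0.27 log units; within the scatter). Neither leaves the scatter, so the expected change is a 1.1-fold higher number from compound 2 to compound 4 (0.05 log units; within the scatter), with no shift beyond the scatter in either direction. Compound 4 is estimated at 23000 nM, with an expected range from 11000 nM to 46000 nM.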

Compound 4, half-maximal inhibitory concentration: 25600 nM
For compound 4 the middle estimate is 1.1-fold (0.05 log units) below the measured one; measured number inside the range.
By their numbers in this assay, from the lowest: compounds 2, 4, 1 and 3 (each within the scatter of the next).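

In this assay, replacing the methoxy on the aromatic carbon para to a large group with hydrogen gives a 1.2-fold higher number from compound 2 to compound 4 (0.10 log units; within the scatter), the first step shown that changes this position alone. On this read-out, 3,4,5-trimethoxyphenyl and 3,5-dimethoxyphenyl therefore cannot be told apart when the oxolan-3-yl group stays in place. Nothing available explains this result. Still open, going by these compounds, is whether an amine or a carboxylic acid on this carbon would give a step beyond the scatter. The same question stands for replacing the two remaining methoxy groups with hydrogen.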